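A few compounds are considered here, and "the series" means these few. Any claim that something is new, unique, unknown or untested is made for them only; others in the source may bear on it.

For the measured compounds named here, compound 1 `CSc1ccc(CNc2nc(SC)nc3ncccc23)cc1` stands lowest of the two numbers measured so far: in a functional assay on HT-29 cells (Homo sapiens) for cytotoxicity, read by MTT assay, with a stated time of 72 h (on this read-out higher numbers stand for weaker inhibition of growth and lower numbers for stronger inhibition of growth), compound 1 gives 4320 nM. Compound 2 `COc1ccc(CNc2nc([SeH])nc3ccccc23)cc1` gives 71600 nM in this assay, a far higher number, but compound 2 differs from compound 1 in more than one place, so the two values only show where each compound stands. Compound 3 `COc1ccc(CNc2nc(SC)nc3ncccc23)cc1` has not been measured yet and differs from compound 1 in a single place: methoxy in place of methylsulfanyl on an aromatic carbon. Going by the values given here, no measured pair shows this change, so a small step is expected, slightly weaker at most and likely within the usual scatter: a 1.4-fold higher number from compound 1 to compound 3 (0.14 log units; within the scatter). Compound 3 is therefore expected to give about 6000 nM in this assay, with a range from 2500 nM to 15000 nM.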

Compound 3, concentration for 50% growth inhibition: > 100000 nM
Compound 3 gave a limit, no number; the forecaster's own chance of this, stated with the estimate: 3%; middle value at least 16-fold (1.22 log units) from the limit.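

In this assay compound 3 gives > 100000 nM as a limit of the assay and not as a number. On this aromatic carbon, para to a large group, methoxy in place of methylsulfanyl gives an at least 23-fold higher number from compound 1 to compound 3 (1.36 log units; beyond the scatter) even though the two groups have the same counts of heavy atoms and hydrogen-bond acceptors, so this position does not treat them alike. The full size of this step stays unknown since it rests on a limit: the limit of > 100000 nM in this assay, at which 1 of the 3 values shown sits.

What the compounds shown leave open is how other groups would fare at this position, such as an ethylsulfanyl, a chlorine or an amine. They also cannot say why methylsulfanyl and methoxy differ so much here.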